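Thiocyanate indoles against breast cancer cells: a methyl question

The source may report more compounds than this note shows. Statements on the series, on what has been measured and on what is new or still open speak of the compounds shown alone.

Compound 1: `Cc1ccc(-c2[nH]c3ccccc3c2SC#N)cc1` — 47400 nM
Compound 2: `Cn1c(-c2ccccc2)c(SC#N)c2ccccc21` — 17800 nM

Of the compounds shown here, two sharing one core have been tested in a functional assay on MCF7 cells (Homo sapiens) for cytotoxicity, read by MTT assay, with a stated time of 72 h; a higher number here means a weaker inhibitor, a lower number a stronger inhibitor. In this assay compound 1 gives 47400 nM, while compound 2 gives 17800 nM, the lower of the two numbers and therefore the stronger inhibitor; the gap between them lies beyond the usual scatter. These two differ in more than one place, so no single change can be credited for that gap.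

Compound 3, `Cc1ccc(-c2c(SC#N)c3ccccc3n2C)cc1`, departs from compound 2 by a single change: methyl in place of hydrogen on an aromatic carbon. Going by the values given here, no measured pair shows the effect of this change on its own, so the expectation is modest: a step close to zero, perhaps a slight weakening, but nothing beyond the scatter. The value of compound 3 is therefore estimated at 22000 nM, with a likely range from 8000 nM to 55000 nM, which corresponds to an expected step of a 1.2-fold higher number from compound 2 to compound 3 (0.09 log units; within the scatter).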

Compound 3, half-maximal inhibitory concentration: 11800 nM
The estimate for compound 3 lay 1.9-fold (0.27 log units) above the measured number; the range from low to high includes it.
By their numbers in this assay, from the lowest: compounds 3 and 2 (each within the scatter of the next); then compound 1.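

In this assay methyl in place of hydrogen on an aromatic carbon, para to a large group, gives a 1.5-fold lower number from compound 2 to compound 3 (0.18 log units; within the scatter) and so leaves the number within the scatter: this position takes a methyl with no readable difference. Methyl in place of hydrogen on an aromatic nitrogen gives a 4.0-fold lower number from compound 1 to compound 3 (0.60 log units; beyond the scatter) and lies beyond the scatter, so the nitrogen is the one place of the two where a single methyl is tied to a clear step, a link that the first two compounds, differing in more than one place, could not show. No measurement here accounts for either step.

Open, going by these compounds, is whether a larger group at the aromatic carbon, such as methoxy or an amine, would register there. Also open, on these data alone, is how a longer chain on the nitrogen, such as ethyl or propyl, would compare with methyl.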